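Chalcone Series on the Boron-Containing Core: Aryl Ketone Variation

The source may hold more compounds than are shown below. What is called first, only, known or untested is meant among the compounds shown, and "the series" means these compounds.

Three compounds share the core seen in compound 1 `O=C(/C=C/c1ccc2c(c1)B(O)OC2)c1cccnc1` and differ only in the aryl group on the carbonyl carbon. In a functional assay on MDA-MB-231 cells (Homo sapiens) for cytotoxicity, read by MTT assay, with a stated time of 48 h (a lower number here means a stronger inhibitor, a higher number a weaker inhibitor), compound 1 gives 11400 nM, the highest of the three numbers, though all three lie within the scatter of one another. Compound 2 `CCc1ccc(C(=O)/C=C/c2ccc3c(c2)B(O)OC3)cc1` gives 9800 nM and compound 3 `O=C(/C=C/c1ccc2c(c1)B(O)OC2)c1ccc(C(F)(F)F)cc1` gives 9200 nM. Going by the values given here, the only single-point step among them, a 1.1-fold lower number from compound 2 to compound 3 (0.03 log units; within the scatter), concerns a substituent swap on an aromatic carbon and not the exchange of the whole aryl group.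

Compound 4 `O=C(/C=C/c1ccc2c(c1)B(O)OC2)c1ccccc1O` is not yet measured. It differs from compound 1 by 2-hydroxyphenyl in place of pyridin-3-yl on a carbonyl carbon. Among the compounds with values here, no measured step bears directly on the replacement of one aryl group by another; the indirect evidence is that compound 1, compound 2 and compound 3 hold three different aryl groups at the same place and their values in this assay fall within the scatter of each other. On that basis no step beyond the scatter is expected, and the estimate for compound 4 amounts to a 1.1-fold lower number from compound 1 to compound 4 (0.06 log units; within the scatter). For compound 4 the expected value is therefore 10000 nM, with a range from 4000 nM to 25000 nM.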

Compound 4, half-maximal inhibitory concentration: 16900 nM
For compound 4 the middle estimate is 1.7-fold (0.23 log units) below the measured one; the range from low to high includes it.
By their numbers in this assay, from the lowest: compounds 3, 2, 1 and 4 (each within the scatter of the next).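

In this assay, going by these compounds alone, the exchange of pyridin-3-yl for 2-hydroxyphenyl on a carbonyl carbon reads as a 1.5-fold higher number from compound 1 to compound 4 (0.17 log units; within the scatter) and is the only direct reading here of one whole aryl group replaced by another at this place. The step stays within the scatter although the entering group carries a hydrogen-bond donor and the leaving group carries none, so in this single pair the presence of that donor does not separate the two compounds. Nothing at hand gives a measured basis for interpreting this pair beyond the values themselves.

All four groups on the carbonyl carbon are six-membered aromatic rings, which leaves open whether a group of another kind there, such as a saturated piperidine ring or a plain methyl, would give a step beyond the scatter. Also open, from the compounds shown here alone, is whether the hydroxyl group of 2-hydroxyphenyl has any bearing on the value, and whether a phenyl ring carrying a methoxy group, an amine or a carboxylic acid would read any differently from compound 4 in this assay.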